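Methyl removal on the anilino ring of a dichloropyrimidine diamine

This account rests on a few compounds, and the source may have more. Where it says the series, first, only, none or still open, it means among the compounds named here.

Measured compounds:
compound 1, `Cc1ccccc1Nc1nc(Nc2ccccc2)ncc1Cl`: > 100000 nM
compound 2, `Cc1ccc(Nc2ncc(Cl)c(Nc3ccccc3C)n2)cc1`: > 100000 nM
compound 3, `Cc1ccccc1Nc1nc(Nc2ccc(N3CCN(C)CC3)cn2)ncc1Cl`: 7470 nM

In a functional assay on MDA-MB-231 cells (Homo sapiens) for inhibition, read by CCK-8 assay, with a stated time of 48 h (on this read-out higher numbers stand for weaker inhibition of growth and lower numbers for stronger inhibition of growth), compound 1 reaches only a limit, > 100000 nM. Compound 2 likewise gives only a limit, > 100000 nM. Going by the values given here, compound 3 is the one compound with a number, 7470 nM. The difference between the cores of compound 2 and compound 3 is not broken down here. The change from compound 2 to compound 1, (hydrogen in place of methyl on an aromatic carbon), gives a step that the two limits leave unreadable from compound 2 to compound 1; the two limits leave its size unreadable, as the limit of > 100000 nM in this assay, at which 2 of the 3 values shown sit, shows. Compound 4, `CN1CCN(c2ccc(Nc3ncc(Cl)c(Nc4ccccc4)n3)nc2)CC1`, not yet measured, carries the same kind of change, (hydrogen in place of methyl on an aromatic carbon), the place being ortho to a large group rather than para to a large group. With no readable precedent, the step from compound 3 to compound 4 is estimated as a 1.5-fold higher number from compound 3 to compound 4 (0.17 log units; within the scatter). Compound 4 is expected at 11000 nM, between 3000 nM and 40000 nM.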

Compound 4, concentration for 50% growth inhibition: 37400 nM
Estimate against measurement, compound 4: 3.4-fold (0.53 log units) below, within the range that was stated.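

In this assay, hydrogen in place of methyl, which turns 2-methylphenyl into phenyl, gives a 5.0-fold higher number from compound 3 to compound 4 (0.70 log units; beyond the scatter), a step beyond the scatter on this core. The same change on the core of compound 2 cannot be read, because compound 1 and compound 2 both stand at a limit of the assay and neither gives a number: the limit of > 100000 nM in this assay, at which 2 of the 4 values shown sit. The series therefore offers one readable instance of this change, which shows its size on one core but does not show whether that size carries over to another core.

The compounds shown leave open how an ethyl or a methoxy group would read in place of that methyl on the core of compound 3. They also leave open whether a fluorine or an amine at the same place would give a different step.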